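The source may hold more compounds than are shown below. What is called first, only, known or untested is meant among the compounds shown, and "the series" means these compounds.

Compound 3, `CCc1nc2cc(Cl)ccn2c1C(=O)NCc1ccc(N2CCN(C(C)C)CC2)cc1`, gives > 2 h in an ADME assay (liver) for metabolic stability, with Liver microsome (Homo sapiens) as the target, using microsomes (on this read-out lower numbers stand for a shorter-lived compound and higher numbers for a longer-lived compound), which is a limit of the assay and not a number. Compound 1, `CCc1nc2cc(Cl)ccn2c1C(=O)NCc1ccc(-c2ccc(Cl)cc2)cc1`, gives > 2 h, also a limit. Compound 2, `CCc1nc2cc(Cl)ccn2c1C(=O)NCc1ccc(-c2ccncc2)cc1`, gives 0.482 h. Compound 4, `CCc1nc2cc(Cl)ccn2c1C(=O)NCc1ccc(N2CCN(c3ccc(OC(F)(F)F)cc3)CC2)cc1`, carries 4-(trifluoromethoxy)phenyl in place of isopropyl on an amine nitrogen in a ring.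

Going by the values given here, no measured step touches that nitrogen, so the evidence is indirect and comes from changes on an aromatic carbon. The record shows an at least 4.1-fold lower number from compound 1 to compound 2 (0.61 log units; beyond the scatter) and an at least 4.1-fold higher number from compound 2 to compound 3 (0.61 log units; beyond the scatter), while a step that the two limits leave unreadable from compound 1 to compound 3 cannot be sized. Only the pyridin-4-yl of compound 2 goes with a shorter half-life, at 0.482 h. The entering group has an aromatic ring of carbon only, as does the 4-chlorophenyl of compound 1, so no step beyond the scatter is expected. The expected step is a step that the limit leaves unreadable from compound 3 to compound 4. In this assay, compound 4 is estimated at 2.2 h, with an expected range of 0.8 h to 5 h.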

Compound 4, half-life: > 2 h
Compound 4: no number, only a limit; the forecaster's own chance of this, stated with the estimate: 60%; the middle value is on the limit's open side.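

In this assay, going by these compounds alone, compound 3 and compound 4 both stand as limits and not as numbers, so no step between them can be read: the limit of > 2 h in this assay, at which 3 of the 4 values shown sit. On these data alone, whether 4-(trifluoromethoxy)phenyl in place of isopropyl shifts the half-life at all, and how far, stays open.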